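The source may report more compounds than this note shows. Statements on the series, on what has been measured and on what is new or still open speak of the compounds shown alone.

Measured compounds in the series:
- compound 1 `CCOC(=O)c1c(-c2cc3ccccc3oc2=O)nn(-c2ccccc2)c1C(=O)OCC` in a functional assay on DU-145 cells (Homo sapiens) for cytotoxicity, read by MTT assay, with a stated time of 48 h (on this read-out higher numbers stand for weaker inhibition and lower numbers for stronger inhibition), gives 57000 nM
- compound 2 `COC(=O)c1c(-c2cc3ccccc3oc2=O)nn(-c2cccc(Cl)c2)c1C(=O)OC` in this assay gives 32000 nM
- compound 3 `CCOC(=O)c1c(-c2cc3ccccc3oc2=O)nn(-c2ccc(Br)cc2)c1C(=O)OCC` in this assay gives 61000 nM

Compound 2 has the lowest of the three numbers, but its gap to compound 1 and to compound 3 both lie within the scatter, so no order among the three can be read. The step to the unmeasured compound 4 `COC(=O)c1c(-c2cc3ccccc3oc2=O)nn(-c2ccc(Br)cc2)c1C(=O)OC` is 4-bromophenyl in place of 3-chlorophenyl on an aromatic nitrogen. Among the measured compounds shown here, the only measured step bearing on the aryl substituent is a 1.1-fold higher number from compound 1 to compound 3 (0.03 log units; within the scatter), which shows that placing bromine on the phenyl ring left the number within the scatter. For the measured compounds named here, no measured step isolates the exchange of chlorine for bromine or the move of the halogen, and compound 4 also shares its methyl esters with compound 2 while compound 3 carries ethyl esters; the values of compound 2 and compound 3 lie within the scatter of each other. Compound 4 is therefore expected to sit close to compound 2, with a 1.4-fold higher number from compound 2 to compound 4 (0.15 log units; within the scatter) in this assay, no shift beyond the scatter. The estimate for compound 4 is 45000 nM, expected within 20000 nM to 100000 nM.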

Compound 4, half-maximal inhibitory concentration: 93000 nM
Compound 4: the middle estimate sits 2.1-fold (0.32 log units) below what was measured, and the stated range covers the measured number.
By their numbers in this assay, from the lowest: compounds 2, 1, 3 and 4 (each within the scatter of the next, the first and the last beyond it).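

In this assay, among the compounds shown here, the substituent on the aromatic nitrogen of the methyl ester pair matters more than the earlier compounds indicated: 4-bromophenyl in place of 3-chlorophenyl gives a 2.9-fold higher number from compound 2 to compound 4 (0.46 log units; beyond the scatter), a modest step toward weaker inhibition. For the compounds shown here, the only earlier step at this position, among the ethyl esters, was a 1.1-fold higher number from compound 1 to compound 3 (0.03 log units; within the scatter), so this is the first change on the aryl group that clears the scatter. No measurement on hand accounts for the step.

Going by these compounds alone, the exchange alters both the halogen and its place on the phenyl ring, and no pair here separates the two, so either could carry the step. Also open, on these data alone, is how an amine on the phenyl ring, or a carboxylic acid in place of the ester groups, would read in this assay.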